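The source may report more compounds than this note shows. Statements on the series, on what has been measured and on what is new or still open speak of the compounds shown alone.

In a functional assay on IGROV-1 cells (Homo sapiens) for inhibition, read by sulforhodamine B assay, with a stated time of 48 h, tested at 10 uM (a higher number here means more inhibition at the concentration tested (going by the name of the read-out), a lower number less inhibition), compound 1 `COc1ccc(-c2cn3ccnc3c(-c3ccc4ncn(C5CCCCC5)c4c3)n2)cc1` gives 53.4%, and compound 2 `O=Cc1ccc(-c2cn3ccnc3c(-c3ccc4ncn(C5CCCCC5)c4c3)n2)cc1` gives 21.3%, the lower of the two numbers. Among the measured compounds shown here, the only measured step, a number 32.1 percentage points lower from compound 1 to compound 2 (beyond the scatter), shows that a change at this one position can move the read-out a long way. Compound 3 `Clc1ccc(-c2cn3ccnc3c(-c3ccc4ncn(C5CCCCC5)c4c3)n2)cc1` differs from compound 2 by chloro in place of formyl on an aromatic carbon. For the measured compounds named here, no measured step covers a chloro at this position, so the direction of the change is uncertain, though a step of some size is expected. For compound 3 the estimated step is a number 18.7 percentage points higher from compound 2 to compound 3 (beyond the scatter), giving an expected value of 40% with a range from 15% to 65%.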

Compound 3, a percentage reported as inhibition, at one concentration (the size of the read-out at that concentration, not a potency): 7.84%
The estimate for compound 3 lay 32.2 percentage points above the measured number; measured number below the stated range.
By their numbers in this assay, from the lowest: compound 3; then compound 2; then compound 1.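

The 4-chlorophenyl group gives a number 13.5 percentage points lower from compound 2 to compound 3 (beyond the scatter) and a number 45.6 percentage points lower from compound 1 to compound 3 (beyond the scatter) at this position, so the number falls further than it did with formyl. Of the three groups, methoxy in compound 1 now stands highest, beyond the scatter against both others, while formyl and chloro both lose much of the inhibition. Nothing measured here explains why this position responds in this way. Still open, on these data alone, is whether an amine, a carboxylic acid or a longer chain such as ethoxy would match or pass methoxy at this position.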